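From 3-hydroxypropoxy to benzyloxy on a shared core

A few compounds are considered here, and "the series" means these few. Any claim that something is new, unique, unknown or untested is made for them only; others in the source may bear on it.

In a functional assay on HL-60 cells (Homo sapiens) for cytotoxicity, read by MTT assay, with a stated time of 24 h (a lower number here means a stronger inhibitor, a higher number a weaker inhibitor), compound 1 (`Brc1ccc(Oc2cc(Br)cc(Br)c2OCCCCCN2CCN(c3ccccc3)CC2)c(Br)c1`) gives 41.6 ug/mL and compound 2 (`OCCCOc1c(Br)cc(Br)cc1Oc1ccc(Br)cc1Br`) gives 29.9 ug/mL as the half-maximal inhibitory concentration. These two values lie within the usual scatter of each other, so compound 2 cannot be ranked against compound 1, although the two structures carry very different chains on the shared core.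

Compound 3 (`Brc1ccc(Oc2cc(Br)cc(Br)c2OCc2ccccc2)c(Br)c1`) departs from compound 2 in one place: phenyl in place of 2-hydroxyethyl on a saturated chain carbon bound to an oxygen on an aromatic ring with phenyl in place of 2-hydroxyethyl on a saturated chain carbon bound to an oxygen on an aromatic ring. Cut one bond further out, the same change reads 3-hydroxypropoxy to benzyloxy.

For the measured compounds named here, no measured step shows what this change does. Going by the values given here, the only guide is that compound 1 at 41.6 ug/mL and compound 2 at 29.9 ug/mL sit within the scatter despite their different chains, so no step beyond the scatter is expected in this assay in either direction. The expected step of a 1.0-fold higher number from compound 2 to compound 3 (0.00 log units; within the scatter) is thus an estimate with little behind it. Compound 3 is estimated at 30 ug/mL with an expected range of 12 ug/mL to 75 ug/mL in this test.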

Compound 3, half-maximal inhibitory concentration: 27.9 ug/mL
Estimate against measurement, compound 3: 1.1-fold (0.03 log units) above, within the range that was stated.
By their numbers in this assay, from the lowest: compounds 3, 2 and 1 (each within the scatter of the next).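

In this assay, for the compounds shown here, putting phenyl in place of 2-hydroxyethyl on a saturated chain carbon bound to an oxygen on an aromatic ring comes to a 1.1-fold lower number from compound 2 to compound 3 (0.03 log units; within the scatter), the first step that can be read at this place on the shared core. The change is not a small one in structure: the chain loses its hydrogen-bond donor and its hydrogen-bond acceptor and gains a six-membered aromatic ring of carbon only, yet the read-out does not separate the two compounds, so in this pair neither 3-hydroxypropoxy nor benzyloxy can be ranked above the other. Nothing available here bears on why the two numbers lie so close.

What the compounds shown leave open is whether any group at this place gives a step beyond the scatter, for instance a carboxylic acid or a simple amine at the end of the chain, or a longer chain ending in a hydroxyl. They also leave open whether a benzyl group with a substituent on its ring would read the same as the plain benzyl of compound 3.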